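Replacing the 4-bromo-2-fluorophenyl group of compound 1

The compounds below may be only part of what the source reports. "The series", "measured", "known", "first", "only" and "open" are said of these compounds alone.

Measured values in a functional assay on HeLa cells (Homo sapiens) for antiproliferative activity, read by MTT assay, with a stated time of 72 h (a higher number here means a weaker inhibitor, a lower number a stronger inhibitor), are as follows
- compound 1 `CCNC(=O)c1cc(Oc2ccc(NC(=O)c3nn(-c4ccc(Br)cc4F)c(=O)cc3C)cc2)ccn1` gives "not active" (no number reported)
- compound 2 `CCCNC(=O)c1cc(Oc2ccc(NC(=O)c3nn(-c4ccc(C)cc4)c(=O)cc3C)cc2F)ccn1` gives 14200 nM
- compound 3 `CNC(=O)c1cc(Oc2ccc(NC(=O)c3nn(-c4ccccc4Cl)c(=O)cc3C)cc2F)ccn1` gives 9870 nM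

Compound 1 has no single number, so its place among the others cannot be fixed on a numerical scale. Compound 4 `CCNC(=O)c1cc(Oc2ccc(NC(=O)c3nn(-c4ccc(C)cc4)c(=O)cc3C)cc2)ccn1` has not yet been measured. It differs from compound 1 by 4-methylphenyl in place of 4-bromo-2-fluorophenyl on an aromatic nitrogen, with 4-methylphenyl in place of 4-bromo-2-fluorophenyl on an aromatic nitrogen. Compound 2 also carries 4-methylphenyl and gives 14200 nM in this assay, though it differs from compound 4 elsewhere. A modest step toward stronger inhibition is therefore expected, from no measurable number to a weak one, but its size cannot be calculated. For compound 4 the estimated value is 15000 nM, with an expected range from 6000 nM to 40000 nM in this assay as well.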

Compound 4, half-maximal inhibitory concentration: 10700 nM
Compound 4: the middle estimate sits 1.4-fold (0.15 log units) above what was measured; measured number inside the range.
By their numbers in this assay, from the lowest: compounds 3, 4 and 2 (each within the scatter of the next).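

In this assay, among these compounds, compound 1 gives "not active" (no number reported), so no step from it to compound 4 can be read. No evidence bears on this result. The compounds shown leave open what 4-methylphenyl alone changes.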